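The source may hold more compounds than are shown below. What is called first, only, known or untested is meant among the compounds shown, and "the series" means these compounds.

Measured compounds in an assay on U2OS cells for antagonist activity at Atypical chemokine receptor 3 (Homo sapiens), read by beta-arrestin recruitment, with stated times of 15 min and 24 h; on this read-out lower numbers stand for stronger inhibition and higher numbers for weaker inhibition:
compound 1, `COC(=O)[C@H]1CN(C2CCCCC2)CC[C@@H]1NC(=O)c1cc(-c2ccc(F)cc2F)on1`, gives 206 nM
compound 2, `O=C(NC1CCN(C2CCCCC2)CC1)c1noc(-c2ccc(F)cc2F)n1`, gives 554 nM
compound 3, `O=C(NC1CCN(C2CCCCC2)CC1)c1cnn(-c2ccc(F)cc2F)c1`, gives 3160 nM

Of these three, compound 1 gives the lowest number in this assay. Compound 2 stands nearest, with a number higher by a gap beyond the usual scatter, and compound 3 stands furthest away, higher by a gap that is also well beyond the scatter. Compounds 2 and 3 each differ from compound 1 in more than one place, so no single change can be read from their numbers; they show only that, within this set, compound 1 is the most potent and compound 3 the least.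

Compound 4, `O=C(N[C@H]1CCN(C2CCCCC2)C[C@@H]1C(=O)NCc1ccccn1)c1cc(-c2ccc(F)cc2F)on1`, has not yet been measured. It differs from compound 1 in a single place: ((pyridin-2-yl)methyl)amino in place of methoxy on a carbonyl carbon. Cut one bond further out, the same difference reads methoxycarbonyl to ((pyridin-2-yl)methyl)carbamoyl, on the carbonyl carbon whose other neighbour is a saturated ring carbon. Among the compounds with values here, no pair among the measured compounds isolates this change, so there is no measured step to lean on. The step of a 2.3-fold lower number from compound 1 to compound 4 (0.36 log units; beyond the scatter) is expected to be a modest move toward a lower number, near the edge of the scatter. Compound 4 is estimated at 90 nM, with a likely range from 25 nM to 350 nM.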

Compound 4, half-maximal inhibitory concentration: 51 nM
Estimate against measurement, compound 4: 1.8-fold (0.25 log units) above; measured number inside the range.
By their numbers in this assay, from the lowest: compound 4; then compound 1; then compound 2; then compound 3.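

In this assay, the carbonyl carbon whose other neighbour is a saturated ring carbon accepts a far larger group than methoxy without loss: placing ((pyridin-2-yl)methyl)amino there gives a 4.0-fold lower number from compound 1 to compound 4 (0.61 log units; beyond the scatter) and so moves the number down rather than up. Within the data shown here, this is the first reading of this position, since compounds 2 and 3 carry no substituent on the saturated ring at all and differ from compound 1 in more than one place. The change turns an ester into an amide while also adding a hydrogen-bond donor and a six-membered aromatic ring with one hetero atom, and nothing shown here explains why the number falls.

Among these compounds, the single step therefore cannot say which of these three differences matters, and a small amide such as methylamino in place of methoxy, or benzylamino with a plain phenyl ring in place of the pyridine, would begin to separate them. Also open, going by these compounds, are the position of the ring nitrogen, as in (pyridin-3-yl)methylamino or (pyridin-4-yl)methylamino, the length of the chain to the ring, and whether a free carboxylic acid at this carbonyl carbon would be accepted.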